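Dropping One Chloro From a Dichlorophenyl Ether

The source may report more compounds than this note shows. Statements on the series, on what has been measured and on what is new or still open speak of the compounds shown alone.

Compound 1 `NC1=NC2(CCSCC2)N(OCCCOc2ccc(Cl)c(Cl)c2)C(N)=N1` — 89.8%
Compound 2 `NC1=NC2(CCSCC2)N(OCCCOc2cccc(Cl)c2)C(N)=N1` — 88.8%
Compound 3 `NC1=NC2(CCOCC2)N(OCCCOc2cccc(Cl)c2Cl)C(N)=N1` — 89.8%

All three were tested in an assay on isolated protein for inhibition of Dihydrofolate reductase (Homo sapiens), read by spectrophotometry, using NADPH, with stated times of 5 s and 6 min, tested at 50 uM; a higher number here means a stronger effect of the compound at the concentration tested, a lower number a weaker effect. Compound 2 differs from compound 1 by hydrogen in place of chloro on an aromatic carbon, and this step gave a number 1 percentage points lower from compound 1 to compound 2 (within the scatter). The difference between the core of compound 1 and the core of compound 3 is not broken down here.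

Compound 4 `NC1=NC2(CCOCC2)N(OCCCOc2ccccc2Cl)C(N)=N1` has not yet been measured. It differs from compound 3 by hydrogen in place of chloro on an aromatic carbon. This is the same kind of change as that from compound 1 to compound 2, though the surroundings differ: in compound 1 the departing chloro is para to a large group, in compound 3 it is meta to a large group. Because the earlier step was a number 1 percentage points lower from compound 1 to compound 2 (within the scatter), a similarly small step is expected for compound 4, namely a number 1.8 percentage points lower from compound 3 to compound 4 (within the scatter). Compound 4 is therefore estimated at 88%, expected between 81% and 94%.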

Compound 4, a percentage reported as inhibition, at one concentration (the size of the read-out at that concentration, not a potency): 88.2%
Estimate against measurement, compound 4: 0.2 percentage points below, and the stated range covers the measured number.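

In this assay, putting hydrogen in place of a chloro gave a number 1.6 percentage points lower from compound 3 to compound 4 (within the scatter), and this step can be set beside the one seen on the other core: the same change on two cores in this assay, a number 1 percentage points lower (within the scatter) from compound 1 to compound 2 and a number 1.6 percentage points lower (within the scatter) from compound 3 to compound 4, 0.6 percentage points apart, within the scatter of two such steps. In these two pairs, then, the change carries from one core to the other without a detectable difference. This does not show that it would carry to any further core, and a read-out at a single concentration gives only the size of the effect at that concentration, so compounds that read alike here may still show a stronger or weaker effect at other concentrations.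

All the compounds shown keep at least one chloro on the phenyl ring. Still open, on these data alone, is how a ring with no chloro, a methoxy group or an amine in its place, or a longer chain would read.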